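The compounds below may be only part of what the source reports. "The series", "measured", "known", "first", "only" and "open" are said of these compounds alone.

Measured so far in a functional assay on HL-60 cells (Homo sapiens) for cytotoxicity, read by MTT assay, with a stated time of 48 h; a higher number here means a weaker inhibitor, a lower number a stronger inhibitor:
compound 1 `Fc1cccc(-c2nc(Nc3ccccc3)c3cc(F)ccc3n2)c1` gives 48300 nM.
compound 2 `Fc1cccc(-c2nc(Nc3cccc(Br)c3)c3cc(F)ccc3n2)c1` returns only a limit of this assay, > 50000 nM.

Going by the values given here, compound 1 holds the only numerical value in this assay; the other entry is a limit, as the limit of > 50000 nM in this assay, at which 1 of the 2 values shown sits, records. Compound 3 `Cc1ccc(Nc2nc(-c3cccc(F)c3)nc3ccc(F)cc23)cc1` is not yet measured; it differs from compound 1 as follows: methyl in place of hydrogen on an aromatic carbon.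

Among the compounds with values here, the one measured step on the same anilino ring is an at least 1.0-fold higher number from compound 1 to compound 2 (0.01 log units; that floor lies within the scatter), which is within the scatter and ends at the limit, so it gives little to work with beyond showing that a substituent there did not sharpen inhibition. Within the data shown here, no step involving a methyl group is available. The expectation for compound 3 is therefore no change beyond the scatter, a step of roughly a 1.0-fold lower number from compound 1 to compound 3 (0.00 log units; within the scatter), with a fair chance that this assay again reports only a limit. Compound 3 is estimated at 48000 nM, within 24000 nM to 96000 nM.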

Compound 3, half-maximal inhibitory concentration: > 50000 nM
Compound 3 was reported as a limit; the forecaster's own chance of this, stated with the estimate: 45%; at least 1.0-fold (0.01 log units) between middle value and limit.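

In this assay, methyl on the anilino ring, para to a large group, gives an at least 1.0-fold higher number from compound 1 to compound 3 (0.01 log units; that floor lies within the scatter), so a carbon substituent at this position brings no sharper inhibition than hydrogen. Together with the bromo of compound 2, this makes two substituted anilino rings with no gain over compound 1, though the step between compound 2 and compound 3 cannot be read because both are limits. Substitution on this ring has so far produced no further numerical value, and the series now sits mostly at one end of the assay range: the limit of > 50000 nM in this assay, at which 2 of the 3 values shown sit.

Going by these compounds, how far compound 2 and compound 3 lie past that limit remains open, as does any ranking between them. Also open, on these data alone, is whether an amine or a carboxylic acid on the anilino ring, or a longer chain in place of methyl, would return a number within the range.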